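Replacing the phenol of compound 2 with trifluoromethyl

The source may report more compounds than this note shows. Statements on the series, on what has been measured and on what is new or still open speak of the compounds shown alone.

Measured compounds:
compound 1 `O=[N+]([O-])C1=Cc2cc(C#Cc3ccc(CO)cc3)ccc2OC1C(F)(F)F` with 2000 nM
compound 2 `O=[N+]([O-])C1=Cc2cc(C#Cc3ccc(O)cc3)ccc2OC1C(F)(F)F` with 5360 nM

In an assay on 1321N1 cells for antagonist activity at P2Y purinoceptor 6 (Homo sapiens), read by FLIPR and calcium flux (a lower number here means a stronger inhibitor, a higher number a weaker inhibitor), compound 1 gives 2000 nM and compound 2 gives 5360 nM. Among the compounds with values here, compound 2 thus carries the highest of the two numbers, its only neighbour being compound 1, which lies a 2.7-fold higher number from compound 1 to compound 2 (0.43 log units; beyond the scatter) away. The change to compound 3 `O=[N+]([O-])C1=Cc2cc(C#Cc3ccc(C(F)(F)F)cc3)ccc2OC1C(F)(F)F` is trifluoromethyl in place of hydroxy on an aromatic carbon. Within the data shown here, only one measured step is available, the one from compound 1 to compound 2, and it is a 2.7-fold higher number from compound 1 to compound 2 (0.43 log units; beyond the scatter). That step concerns hydroxymethyl against hydroxy, not trifluoromethyl, so it speaks to compound 3 only indirectly: it shows that the group at this position moves the number beyond the scatter, and that hydroxy is the weaker of the two groups tried. A modest step in this assay from compound 2 to compound 3, towards a lower number, is therefore expected, though the direction is uncertain. Compound 3 is estimated at 3000 nM, between 800 nM and 12000 nM, which is expected to amount to a 1.8-fold lower number from compound 2 to compound 3 (0.25 log units; within the scatter).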

Compound 3, half-maximal inhibitory concentration: 5220 nM
Beside the measured number, compound 3's estimate is 1.7-fold (0.24 log units) below it; low and high end bracket the measured number.
By their numbers in this assay, from the lowest: compound 1; then compounds 3 and 2 (each within the scatter of the next).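

In this assay, trifluoromethyl in place of hydroxy on this aromatic carbon gives a 1.0-fold lower number from compound 2 to compound 3 (0.01 log units; within the scatter), so at this position a group with no hydrogen-bond donor or acceptor cannot be told apart from hydroxy, which has one of each. Hydroxymethyl now stands apart from both of the other groups, with a 2.6-fold higher number from compound 1 to compound 3 (0.42 log units; beyond the scatter) alongside the earlier 2.7-fold higher number from compound 1 to compound 2 (0.43 log units; beyond the scatter), which leaves compound 1 with the lowest number of the three and compounds 2 and 3 level within the scatter. Nothing available explains why hydroxymethyl differs from the other two groups.

The compounds shown do not settle whether the lower number of compound 1 depends on the oxygen of hydroxymethyl or on the extra carbon that links it to the ring, a question that a plain methyl or a methoxymethyl group at the same place could address. Going by these compounds, it also remains open how an amine, a carboxylic acid or a longer chain such as hydroxyethyl would compare with hydroxymethyl here, and whether any group at this place can reach a number well below that of compound 1.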